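This account rests on a few compounds, and the source may have more. Where it says the series, first, only, none or still open, it means among the compounds named here.

Compound 1 `CCCCc1nc(C(C)C)c(CC(=O)OCCC)c(=O)n1Cc1ccc(-c2ccccc2-c2noc(=O)[nH]2)cc1` gives 12.6% in an ADME assay on microsomes from liver (Mus musculus) for metabolic stability, with a stated time of 30 min; a lower number here means that less of the compound is left, a higher number that more of the compound is left. Compound 2 `CCCCc1nc(C(C)C)c(CC(=O)OC2CC2)c(=O)n1Cc1ccc(-c2ccccc2-c2noc(=O)[nH]2)cc1` gives 11.4% in this assay.

Compound 2 stands lowest of the two numbers in this assay, yet its step to compound 1, a number 1.2 percentage points lower from compound 1 to compound 2 (within the scatter), lies within the scatter. Compound 3 `CCCCc1nc(C(C)C)c(CC(=O)OC2CCCCC2)c(=O)n1Cc1ccc(-c2ccccc2-c2noc(=O)[nH]2)cc1` differs from compound 2 by cyclohexyl in place of cyclopropyl on an oxygen next to a carbonyl group. For the measured compounds named here, only one measured step bears on this change, a number 1.2 percentage points lower from compound 1 to compound 2 (within the scatter), and it was small. A larger ring is now brought in, but the one step shown gives no ground for a shift beyond the scatter, so the step of a number 1.4 percentage points lower from compound 2 to compound 3 (within the scatter) is expected to be small. Compound 3 is estimated at 10%, between 3% and 20%.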

Compound 3, percent of the compound remaining: 14.6%
Estimate against measurement, compound 3: 4.6 percentage points below; the measured number falls inside the stated range.
By their numbers in this assay, from the lowest: compounds 2, 1 and 3 (each within the scatter of the next).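

On an oxygen next to a carbonyl group, cyclohexyl in place of cyclopropyl gives a number 3.2 percentage points higher from compound 2 to compound 3 (within the scatter) in this assay, and cyclohexyl in place of propyl gives a number 2 percentage points higher from compound 1 to compound 3 (within the scatter). Propyl, cyclopropyl and cyclohexyl therefore cannot be told apart at this place by how much compound is left, even with the larger six-membered ring. No measurement shown here offers an explanation for this result. Still open, going by these compounds, is whether an amine or a carboxylic acid at this place would read differently.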